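The source may hold more compounds than are shown below. What is called first, only, known or untested is meant among the compounds shown, and "the series" means these compounds.

In a physicochemical assay for solubility, read by LC-MS, in phosphate buffer, with a stated time of 24 h, at pH 7.4 (on this read-out lower numbers stand for lower solubility and higher numbers for higher solubility), the measured compounds gave the following:

compound 1 `O=C1CCCN1c1cnc(NCc2c(F)ccc3c2CCO3)n2cnnc12`: 640000 nM
compound 2 `CN(c1ccccc1)c1cnc(NCc2c(F)ccc3c2CCO3)n2cnnc12`: < 2000 nM, which is a limit of the assay rather than a number
compound 3 `O=C1CC2(CC2)CN1c1cnc(NCc2c(F)ccc3c2CCO3)n2cnnc12`: 130000 nM

Within the data shown here, compound 3 stands lowest of the two numbers given; the only other number lies above it by the step of a 4.9-fold lower number from compound 1 to compound 3 (0.69 log units; beyond the scatter), and the remaining value is a limit.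

Compound 4 `Fc1ccc2c(c1CNc1ncc(Nc3ccccc3)c3nncn13)CCO2` has not yet been measured. It differs from compound 3 in one place: a group of 7 heavy atoms (6 carbon, 1 nitrogen; one six-membered aromatic ring of carbon only) in place of a group of 8 heavy atoms (6 carbon, 1 nitrogen, 1 oxygen; one three-membered non-aromatic ring of carbon only, one five-membered non-aromatic ring with 1 hetero atom), on an aromatic carbon.

Among the measured compounds shown here, two measured steps bear on this change. Replacing the spirocyclic lactam of compound 3 with a methyl(phenyl)amino group is the reverse of an at least 65-fold higher number from compound 2 to compound 3 (1.81 log units; beyond the scatter), a large move downward, and the same kind of exchange on compound 1 gave an at least 320-fold lower number from compound 1 to compound 2 (2.50 log units; beyond the scatter). In both cases the phenyl-bearing amine ended at the limit of < 2000 nM in this assay, at which 1 of the 3 values shown sits. The anilino group entering in compound 4 shares the six-membered aromatic ring of carbon only with that amine and adds one hydrogen-bond donor, so a large downward step in this assay is expected, a 52-fold lower number from compound 3 to compound 4 (1.72 log units; beyond the scatter), with a real chance that only a limit is reported.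

For compound 4 the estimated solubility in this assay is 2500 nM, within a range from 500 nM to 15000 nM.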

Compound 4, solubility: 3000 nM
Compound 4: the middle estimate sits 1.2-fold (0.08 log units) below what was measured; measured number inside the range.
By their numbers in this assay, from the lowest: compound 4; then compound 3; then compound 1. At a limit, below all of these: compound 2.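

In this assay, the anilino group on this aromatic carbon sits far under both ring groups it can be compared with, as shown by a 43-fold lower number from compound 3 to compound 4 (1.64 log units; beyond the scatter) and by a 210-fold lower number from compound 1 to compound 4 (2.33 log units; beyond the scatter). Earlier, the drop on leaving those ring groups for a phenyl-bearing amine ended only at a limit, whereas this position now gives a real number for such an amine, so the size of the drop can be read directly. Hydrogen in place of methyl on the nitrogen is the step of an at least 1.5-fold higher number from compound 2 to compound 4 (0.17 log units; that floor lies within the scatter), so no gain from removing the methyl can be claimed, and compound 2 is a limit of the assay, not a number: the limit of < 2000 nM in this assay, at which 1 of the 4 values shown sits.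

Open, from the compounds shown here alone, is whether the drop goes with the phenyl ring itself or with the loss of the lactam carbonyl, which a saturated ring amine such as morpholine or piperidine on the same carbon could help separate. Also open, going by these compounds, is whether a pyridine ring in place of the phenyl ring, or a carboxylic acid on it, would lift the number seen for compound 4.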